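Cytotoxicity notes: from compound 2 to compound 3

This account rests on a few compounds, and the source may have more. Where it says the series, first, only, none or still open, it means among the compounds named here.

Measured so far:
compound 1, `Cc1ccc(C(C)C)c(OC(=O)Nc2ccc([N+](=O)[O-])cc2)c1`: 47.2%
compound 2, `Cc1ccc(C(C)C)cc1OC(=O)NC1CCCC1`: 50.4%

In a toxicity assay on the whole organism (H4IIE cells) for cytotoxicity, with Rattus norvegicus as the target, read by MTT assay, with a stated time of 24 h, tested at 1.25 uM (on this read-out lower numbers stand for a stronger effect and higher numbers for a weaker effect at the one concentration tested), compound 1 gives 47.2% and compound 2 gives 50.4%. Compound 2 holds the larger of the two numbers, but its gap to compound 1 lies within the usual scatter of repeated measurements, so the two compounds cannot be told apart on this read-out; neither is set apart from the other. For the measured compounds named here, no pair of measured compounds differs in one place only, so no single-change step has been measured.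

Compound 3, `Cc1ccc(C(C)C)cc1OC(=O)Nc1cccc(F)c1`, has not yet been measured in this assay. Against compound 2 the change is 3-fluorophenyl in place of cyclopentyl on an amide-type nitrogen. Nothing measured here bears on a change of this kind, so the expectation rests on the two numbers shown, which sit close together. For compound 3 no step beyond the scatter is expected, in either direction, and the expected step from compound 2 is a number 1.4 percentage points lower from compound 2 to compound 3 (within the scatter). Compound 3 is accordingly estimated at 49%, with a range from 38% to 60%.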

Compound 3, a percentage reported as activity, at one concentration (the size of the read-out at that concentration, not a potency): 47.8%
Compound 3: middle estimate off by 1.2 percentage points, on the high side; measured number inside the range.
By their numbers in this assay, from the lowest: compounds 1, 3 and 2 (each within the scatter of the next).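

In this assay the series now has its first step between compounds that differ in one place, a number 2.6 percentage points lower from compound 2 to compound 3 (within the scatter), with 3-fluorophenyl in place of cyclopentyl on an amide-type nitrogen. At this position, a six-membered aromatic ring bearing fluorine and a five-membered non-aromatic ring of carbon only cannot be told apart on this read-out, a point that compound 1 and compound 2 could not address as they differ in more than one place. No available evidence bears on the reason for this result.

The compounds shown leave open whether the same holds for groups of other kinds on this nitrogen, such as a plain phenyl, a longer alkyl chain, an amine-bearing chain or a carboxylic acid-bearing ring. They also leave open what the fluorine contributes on its own, and whether the absence of a step beyond the scatter would persist at concentrations other than the single one tested here.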